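Swapping the Amide Ring Partner in a Weak Lipoxygenase Series

A few compounds are considered here, and "the series" means these few. Any claim that something is new, unique, unknown or untested is made for them only; others in the source may bear on it.

Measured so far, in an assay for inhibition of Polyunsaturated fatty acid 5-lipoxygenase (Homo sapiens); on this read-out lower numbers stand for stronger inhibition and higher numbers for weaker inhibition:
compound 1, `COCCOc1cc(C)c2c(c1C)CC(C(C)C(=O)NC1CCCC1)CC2`, gives only a limit, > 10000 nM
compound 2, `CCCOc1cc(C)c2c(c1C)CC(C(C)C(=O)Nc1ccccn1)CC2`, gives 6000 nM

Among the compounds with values here, compound 2 is the only compound here with an actual number. In this assay compound 2 gives 6000 nM, which is weak inhibition. Compound 1 gives no number at all; for compound 1 the reading is the limit of > 10000 nM in this assay, at which 1 of the 2 values shown sits. Compounds 1 and 2 differ in more than one place. Nothing can be said about what separates them beyond the two readings themselves.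

Compound 3, `CCCOc1cc(C)c2c(c1C)CC(C(C)C(=O)Nc1ncc(C)s1)CC2`, has not been measured. It differs from compound 2 in one place: 5-methyl-1,3-thiazol-2-yl in place of pyridin-2-yl on an amide-type nitrogen. Within the data shown here, both groups are small aromatic rings attached through the same amide-type nitrogen, and no measured pair here shows what such a swap does.

The expectation for the step from compound 2 to compound 3 in this assay is therefore a change of about a 1.2-fold lower number from compound 2 to compound 3 (0.08 log units; within the scatter), that is, none beyond the usual scatter. Compound 3 is estimated at 5000 nM, within a range from 1500 nM to 20000 nM.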

Compound 3, half-maximal inhibitory concentration: 800 nM
Compound 3: the middle estimate sits 6.3-fold (0.80 log units) above what was measured; the measured number lies below the stated range.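

In this assay, placing 5-methyl-1,3-thiazol-2-yl instead of pyridin-2-yl on the amide-type nitrogen gives a 7.5-fold lower number from compound 2 to compound 3 (0.88 log units; beyond the scatter). Within the data shown here, this is the first comparison where only one place differs, and it shows that the choice of aromatic ring at this position can shift the reading, even though both groups have the same number of heavy atoms and attach through the same nitrogen. The swap replaces a six-membered aromatic ring holding one hetero atom with a five-membered aromatic ring holding two, one of them sulfur, but nothing measured here gives a reason for the step.

This single swap changes ring size, ring atoms and the methyl group all at once, so it remains unknown which of these accounts for the step; a plain 1,3-thiazol-2-yl ring with no methyl, or one carrying an ethyl group in its place, would begin to separate them. As far as these compounds go, it is also open whether the same ring partner would give a similar step with a 2-methoxyethoxy chain in place of the propoxy chain on the shared core.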